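Aryl urea series: weakest member and a halogenated aryl replacement

This account rests on a few compounds, and the source may have more. Where it says the series, first, only, none or still open, it means among the compounds named here.

Compounds and values in a functional assay on MGC-803 cells (Homo sapiens) for antiproliferative activity, read by MTT assay, with a stated time of 48 h; on this read-out lower numbers stand for stronger inhibition and higher numbers for weaker inhibition:
compound 1 `O=C(Nc1ccccc1)Nc1cccc(CNc2nccnc2Cl)c1` gives 16300 nM
compound 2 `O=C(Nc1cccc(CNc2nccnc2Cl)c1)Nc1ccccc1F` gives 6440 nM
compound 3 `O=C(Nc1cccc(CNc2nccnc2Cl)c1)NC1CCCC1` gives 23400 nM

Compound 3 gives the highest number of the three; its gap to compound 1 lies within the scatter, and only its gap to compound 2 lies beyond it. Compound 4 `O=C(Nc1cccc(CNc2nccnc2Cl)c1)Nc1ccc(F)c(Cl)c1` is the unmeasured member. Its change from compound 3 is 3-chloro-4-fluorophenyl in place of cyclopentyl on an amide-type nitrogen.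

Within the data shown here, two measured steps bear on this. The step of a 1.4-fold higher number from compound 1 to compound 3 (0.16 log units; within the scatter) shows that the bare aryl and the cyclopentyl are not separated. The step of a 3.6-fold higher number from compound 2 to compound 3 (0.56 log units; beyond the scatter) shows that the fluorinated aryl sits beyond the cyclopentyl, and the step of a 2.5-fold lower number from compound 1 to compound 2 (0.40 log units; beyond the scatter) shows that a halogen on the aryl accounts for that gain. Compound 4 carries two halogens on its aryl, so a lower number than compound 3 is expected, with a step of about a 3.9-fold lower number from compound 3 to compound 4 (0.59 log units; beyond the scatter). For compound 4 in this assay the estimate is 6000 nM, within a range from 2500 nM to 15000 nM.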

Compound 4, half-maximal inhibitory concentration: 5020 nM
Beside the measured number, compound 4's estimate is 1.2-fold (0.08 log units) above it; measured number inside the range.
By their numbers in this assay, from the lowest: compounds 4 and 2 (each within the scatter of the next); then compounds 1 and 3 (each within the scatter of the next).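

In this assay the 3-chloro-4-fluorophenyl on the amide-type nitrogen stands clear of both groups without halogen, with a 4.7-fold lower number from compound 3 to compound 4 (0.67 log units; beyond the scatter) and with a 3.2-fold lower number from compound 1 to compound 4 (0.51 log units; beyond the scatter) as well. Against the 2-fluorophenyl, however, the result is a 1.3-fold lower number from compound 2 to compound 4 (0.11 log units; within the scatter) and so lies within the scatter: the two halogenated aryl groups are not separated, and the series shows no further return from the richer halogen pattern. Nothing shown gives a reason for these steps.

The separate shares of the chlorine and the fluorine in compound 4 remain unresolved, since no aryl carrying chlorine alone appears among these compounds. Also open, on these data alone, is whether halogen is needed at all, which a methoxy, a nitrile, an amine or a carboxylic acid on the same aryl would test.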